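Diethylamino in place of 4-(methylsulfonyl)piperazin-1-yl

This account rests on a few compounds, and the source may have more. Where it says the series, first, only, none or still open, it means among the compounds named here.

In an ADME assay on the whole organism (Rattus norvegicus, strain Sprague-Dawley) for metabolic stability, read by LC-MS, with a stated time of 24 h, at a dose of 1 mg/kg by the intravenous route (on this read-out higher numbers stand for a longer-lived compound and lower numbers for a shorter-lived compound), compound 1 `CCN1C(=O)COc2c(CN3CCN(C(C)=O)CC3)cc(Nc3ncc(F)c(-c4ccc(F)cc4OC)n3)cc21` gives 0.281 h and compound 2 `CCN1C(=O)COc2c(CN3CCN(S(C)(=O)=O)CC3)cc(Nc3ncc(F)c(-c4ccc(F)cc4OC)n3)cc21` gives 0.265 h, so the two values lie within the scatter of each other. For the measured compounds named here, the one measured step is a 1.1-fold lower number from compound 1 to compound 2 (0.03 log units; within the scatter), with methylsulfonyl in place of acetyl on an amine nitrogen in a ring. Compound 3 `CCN(CC)Cc1cc(Nc2ncc(F)c(-c3ccc(F)cc3OC)n2)cc2c1OCC(=O)N2CC` carries diethylamino in place of 4-(methylsulfonyl)piperazin-1-yl on a saturated chain carbon bound to an aromatic carbon. The measured step only swaps a group on the ring nitrogen, whereas here the whole ring leaves, so it is a weak guide. Going by the values given here, no measured compound lacks that ring. The expected change is small and upward, a 1.5-fold higher number from compound 2 to compound 3 (0.18 log units; within the scatter), and it is not expected to clear the scatter. The estimated half-life of compound 3 is 0.4 h, with an expected range of 0.18 h to 1.1 h.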

Compound 3, half-life in the Rattus norvegicus assay: 0.497 h
The estimate for compound 3 lay 1.2-fold (0.09 log units) below the measured number, within the range that was stated.
By their numbers in the Rattus norvegicus assay, from the lowest: compounds 2, 1 and 3 (each within the scatter of the next).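

In the Rattus norvegicus assay, taking the whole ring away from the saturated chain carbon bound to an aromatic carbon gives a 1.9-fold higher number from compound 2 to compound 3 (0.27 log units; within the scatter) and a 1.8-fold higher number from compound 1 to compound 3 (0.25 log units; within the scatter). Neither step clears the scatter, so half-life does not separate the two piperazine compounds from the ring-free diethylamino compound, even though this change is far larger than the swap on the ring nitrogen. In a physicochemical assay for solubility, read by HPLC, in phosphate buffer, measured as kinetic solubility, with a stated time of 24 h, at pH 7.4 (a higher number here means a more soluble compound, a lower number a less soluble compound), compound 2 gives 30.5 ug/mL and compound 3 gives 3.9 ug/mL and so the same change does register, and it comes with no half-life gain beyond the scatter: the measured solubility of compound 2, 30.5 ug/mL, and of compound 3, 3.9 ug/mL, a 7.8-fold lower number (0.89 log units; beyond the scatter)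

The compounds shown leave open whether the solubility step follows the loss of the ring itself or the loss of the methylsulfonyl group and second ring nitrogen. A morpholine or a piperidine on the same carbon would separate these two readings, and would show whether any ring at this position moves half-life beyond the scatter.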